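A methoxy group added to compound 2

The source may hold more compounds than are shown below. What is called first, only, known or untested is meant among the compounds shown, and "the series" means these compounds.

Of the compounds shown here, three built on one shared core have been tested in a functional assay on A549 cells (Homo sapiens) for cytotoxicity, read by WST assay, with a stated time of 48 h; on this read-out higher numbers stand for weaker inhibition and lower numbers for stronger inhibition. Compound 2 (`N#C/C(=C\c1c[nH]c2ccccc12)C(=O)c1c[nH]c2ccccc12`) gives 22000 nM, which places it at the upper end of the numbers, level with compound 1 (`COc1ccc2[nH]cc(/C=C(\C#N)C(=O)c3c[nH]c4ccccc34)c2c1`) at 13700 nM. The step between these two, a 1.6-fold higher number from compound 1 to compound 2 (0.21 log units; within the scatter), shows no real separation. Compound 3 (`COc1ccc(-c2[nH]c3ccccc3c2/C=C(\C#N)C(=O)c2c[nH]c3ccccc23)cc1`) gives 3000 nM, and the step to it, a 7.3-fold lower number from compound 2 to compound 3 (0.87 log units; beyond the scatter), is the only one that clearly exceeds the scatter.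

Compound 4 (`COc1ccc2c(C(=O)/C(C#N)=C/c3c[nH]c4ccccc34)c[nH]c2c1`) has not yet been measured. It differs from compound 2 by a single change: methoxy in place of hydrogen on an aromatic carbon. Going by the values given here, the closest precedent is the pair of compound 1 and compound 2, which differ by the same exchange of methoxy and hydrogen, though compound 1 does not carry its methoxy at the same place as compound 4. That step, a 1.6-fold higher number from compound 1 to compound 2 (0.21 log units; within the scatter), stayed within the scatter. The step to compound 3, a 7.3-fold lower number from compound 2 to compound 3 (0.87 log units; beyond the scatter), involves the larger 4-methoxyphenyl and bears on this change less directly. No shift beyond the scatter is therefore expected, and the estimated step is a 1.5-fold lower number from compound 2 to compound 4 (0.17 log units; within the scatter). For compound 4 the expected value is 15000 nM, with an estimated range of 6500 nM to 32000 nM.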

Compound 4, half-maximal inhibitory concentration: 7500 nM
Estimate against measurement, compound 4: 2.0-fold (0.30 log units) above; the measured number falls inside the stated range.
By their numbers in this assay, from the lowest: compound 3; then compounds 4, 1 and 2 (each within the scatter of the next, the first and the last beyond it).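

In this assay methoxy in place of hydrogen, on an aromatic carbon of a six-membered aromatic ring of carbon only that is meta to a fused ring and para to a fused ring, gives a 2.9-fold lower number from compound 2 to compound 4 (0.47 log units; beyond the scatter) and so moves the number beyond the scatter. The earlier pair did not show this: with the methoxy at the place it holds in compound 1, the exchange gave a 1.6-fold higher number from compound 1 to compound 2 (0.21 log units; within the scatter) and stayed within the scatter, so across these two pairs the outcome of the same exchange depends on where the methoxy stands. Nothing available explains why the two places differ.

The compounds shown leave open whether the step belongs to methoxy in particular, since a hydroxyl, a fluorine, an amine or a longer ethoxy group at this same place could give a step of a different size. They also leave open whether this methoxy and the 4-methoxyphenyl of compound 3 would add up when carried together on the shared core.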